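The compounds below may be only part of what the source reports. "The series", "measured", "known", "first", "only" and "open" are said of these compounds alone.

The measured compounds and their values in a functional assay on PANC-1 cells (Homo sapiens) for inhibition, read by MTT assay, with a stated time of 72 h; a higher number here means a weaker inhibitor of growth, a lower number a stronger inhibitor of growth:
compound 1, `COc1ccc(CNCCCNS(=O)(=O)c2cc(C(F)(F)F)cc(C(F)(F)F)c2)cc1OC`, 18000 nM;
compound 3, `O=S(=O)(NCCCNCc1ccc(Br)cc1)c1cc(C(F)(F)F)cc(C(F)(F)F)c1`, 2200 nM;
compound 2, `CN(CCCNS(=O)(=O)c1cc(C(F)(F)F)cc(C(F)(F)F)c1)Cc1ccccc1`, which reaches only a limit of the assay, > 50000 nM.

Compound 1 stands highest of the two numbers that are given; its nearest neighbour is compound 3, with an 8.2-fold lower number from compound 1 to compound 3 (0.91 log units; beyond the scatter). Compound 4, `COc1ccc(CNCCCNS(=O)(=O)c2cc(C(F)(F)F)cc(C(F)(F)F)c2)cc1`, differs from compound 1 in one place: hydrogen in place of methoxy on an aromatic carbon.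

Two measured steps can be weighed against this change. The step of an 8.2-fold lower number from compound 1 to compound 3 (0.91 log units; beyond the scatter) touches the same ring but exchanges both methoxy groups for a bromine, so it shows only that the 3,4-dimethoxyphenyl is not the better of those two groups in this assay. The step of an at least 22-fold lower number from compound 2 to compound 3 (1.35 log units; beyond the scatter) lies on the amine side of the chain and leaves the ring question open. Going by the values given here, no measured step removes a single methoxy while the other stays. Compound 4 is therefore expected to sit close to compound 1, with at most a modest move toward a lower number, which may well fall within the scatter: the estimate for compound 4 in this assay is 10000 nM, in a range from 4000 nM to 30000 nM, a step of a 1.8-fold lower number from compound 1 to compound 4 (0.26 log units; within the scatter).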

Compound 4, concentration for 50% growth inhibition: 11000 nM
Compound 4: middle estimate off by 1.1-fold (0.04 log units), on the low side; the range from low to high includes it.
By their numbers in this assay, from the lowest: compound 3; then compounds 4 and 1 (each within the scatter of the next). At a limit, above all of these: compound 2.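

Taking away the methoxy ortho to a methoxy group, so that 3,4-dimethoxyphenyl becomes 4-methoxyphenyl, gives a 1.6-fold lower number from compound 1 to compound 4 (0.21 log units; within the scatter) in this assay and so separates hydrogen from methoxy at this position by no more than the scatter. With that methoxy gone the gap to the bromine compound remains, as a 5.0-fold higher number from compound 3 to compound 4 (0.70 log units; beyond the scatter) shows, so the earlier difference between compound 1 and compound 3 does not depend on this methoxy and follows the exchange of the remaining methoxy for bromo. The third step, an at least 4.5-fold lower number from compound 2 to compound 4 (0.65 log units; beyond the scatter) in this assay, is only a bound, and compound 2 gives a limit and no number: the limit of > 50000 nM in this assay, at which 1 of the 4 values shown sits.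

The compounds shown leave open whether the advantage of compound 3 belongs to bromine itself or would also appear with chlorine or a nitrile on the same ring carbon. Also open, going by these compounds, is which part of the change from compound 2 carries its step, the methyl on the amine nitrogen or the substituent on the ring, and how a longer chain between the two nitrogens would read.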